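Removing a bromo group: toxicity on THP-1 cells

A few compounds are considered here, and "the series" means these few. Any claim that something is new, unique, unknown or untested is made for them only; others in the source may bear on it.

Measured compounds:
Compound 1 `Cn1c(-c2ccccc2Br)cnc1NC(=O)c1ccc(F)cc1`: > 100000 nM
Compound 2 `COc1ccc(-c2cnc(NC(=O)c3ccc(C)cc3)n2C)cc1`: > 100000 nM
Compound 3 `COc1ccc(-c2cccc(NC(=O)c3ccc(F)cc3)n2)cc1`: > 100000 nM

All three measured compounds were tested in a toxicity assay on THP-1 cells (Homo sapiens) for inhibition; a higher number here means that more compound is tolerated, a lower number that less compound is tolerated. The value of compound 1 in this assay is a limit of the assay, not a number. The value of compound 2 in this assay is likewise a limit. The same holds for compound 3, whose value in this assay is again a limit. Among the compounds with values here, no compound stands apart: all three sit at the limit of > 100000 nM in this assay, at which 3 of the 3 values shown sit, so compound 1 is neither better nor worse tolerated than the others on the numbers available.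

Compound 4 `Cn1c(-c2ccccc2)cnc1NC(=O)c1ccc(F)cc1` has not yet been measured in this assay. It differs from compound 1 in one place: hydrogen in place of bromo on an aromatic carbon. Within the data shown here, no step between two measured compounds is available to calibrate this change, and the three measured values give no sign that the bromo group matters for tolerance in this assay. Compound 4 is therefore expected to behave like compound 1, with a step that the limit leaves unreadable from compound 1 to compound 4 that stays within the usual scatter. The estimate for compound 4 in this assay is 150000 nM, ranging from 60000 nM to 400000 nM, and most likely the assay will again report only a limit.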

Compound 4, half-maximal cytotoxic concentration: > 100000 nM
Compound 4: no number, only a limit (the forecaster's own chance of this, stated with the estimate: 85%); the middle value does not contradict the limit.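

In this assay, the step from compound 1 to compound 4 cannot be read, because both values are limits of the assay and not numbers: the limit of > 100000 nM in this assay, at which 4 of the 4 values shown sit. The compounds shown leave open whether swapping bromo for hydrogen changes tolerance, and at what concentration any of them would become toxic to these cells.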